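Swapping 1,3-thiazol-2-yl for 3-oxomorpholin-4-yl in compound 3

This account rests on a few compounds, and the source may have more. Where it says the series, first, only, none or still open, it means among the compounds named here.

Measured so far in a physicochemical assay for solubility; on this read-out lower numbers stand for lower solubility and higher numbers for higher solubility 
- Compound 1 `CN1CCN(c2cc(C(F)(F)F)ccc2[C@H]2CCOc3cc(S(=O)(=O)Nc4nccs4)ccc32)CC1` gives 176000 nM 
- Compound 2 `Cn1nccc1-c1cc(C(F)(F)F)ccc1[C@H]1CCOc2cc(S(=O)(=O)Nc3nccs3)ccc21` gives 83000 nM 
- Compound 3 `O=S(=O)(Nc1nccs1)c1ccc2c(c1)OCC[C@@H]2c1ccc(C(F)(F)F)cc1-c1nccs1` gives 15000 nM 

Compound 3 has the lowest number of the three, and both other compounds stand clearly above it. The next compound, compound 4 `O=C1COCCN1c1cc(C(F)(F)F)ccc1[C@H]1CCOc2cc(S(=O)(=O)Nc3nccs3)ccc21`, differs from it on an aromatic carbon, meta to a trifluoromethyl group, and the change is 3-oxomorpholin-4-yl in place of 1,3-thiazol-2-yl on an aromatic carbon. Within the data shown here, three measured steps bear on this, each exchanging the group on an aromatic carbon. The first is a 12-fold lower number from compound 1 to compound 3 (1.07 log units; beyond the scatter), a large step, the second is a 5.5-fold lower number from compound 2 to compound 3 (0.74 log units; beyond the scatter), a modest one, and the third is a 2.1-fold lower number from compound 1 to compound 2 (0.33 log units; beyond the scatter), also modest. Thus 1,3-thiazol-2-yl gave the lowest number among the three groups measured, while no compound carrying 3-oxomorpholin-4-yl has a measured value. Leaving 1,3-thiazol-2-yl is therefore expected to raise the number in this assay by a modest step, and the expected step is a 4.0-fold higher number from compound 3 to compound 4 (0.60 log units; beyond the scatter). For compound 4 the estimate is 60000 nM, with an expected range from 20000 nM to 180000 nM.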

Compound 4, solubility: 695000 nM
The estimate for compound 4 lay 12-fold (1.06 log units) below the measured number, and the stated range ends below it.
By their numbers in this assay, from the lowest: compound 3; then compound 2; then compound 1; then compound 4.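

In this assay the position on the aromatic carbon, meta to a trifluoromethyl group, spans a wider range than the first three compounds showed, with a 46-fold higher number from compound 3 to compound 4 (1.67 log units; beyond the scatter) for the exchange of 1,3-thiazol-2-yl and an 8.4-fold higher number from compound 2 to compound 4 (0.92 log units; beyond the scatter) for the exchange of 1-methyl-1H-pyrazol-5-yl. The 4-methylpiperazin-1-yl group no longer gives the highest number here, as the exchange for 3-oxomorpholin-4-yl brings a 3.9-fold higher number from compound 1 to compound 4 (0.60 log units; beyond the scatter) and the two six-membered non-aromatic rings now stand above the two five-membered aromatic rings, with none of the four compounds going against this order. Nothing at hand explains this order.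

From the compounds shown here alone, it remains open whether the carbonyl of 3-oxomorpholin-4-yl is needed for this high number, which a plain morpholin-4-yl group on the same carbon would test. Going by these compounds, how a carboxylic acid or a primary amine would rank at this place is also open.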